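This account rests on a few compounds, and the source may have more. Where it says the series, first, only, none or still open, it means among the compounds named here.

Three compounds sharing a core were tested in a functional assay for inhibition, with Homo sapiens as the target; on this read-out higher numbers stand for weaker inhibition and lower numbers for stronger inhibition. Compound 2 `Sc1nncc2cncn12` is the plainest of them. In this assay compound 2 gives > 48000 nM, which is a limit of the assay rather than a number. Compound 1 `Cc1nnc(S)n2cncc12` differs from it by methyl in place of hydrogen on an aromatic carbon. In this assay compound 1 gives > 48000 nM, again a limit. The resulting step is a step that the two limits leave unreadable from compound 2 to compound 1. Compound 3 `Cc1nc(C)n2c(S)nncc12` has a core whose difference from that of compound 2 is not broken down here. In this assay compound 3 gives > 48000 nM, also a limit. All three sit at the limit of > 48000 nM in this assay, at which 3 of the 3 values shown sit. Compound 4 `Cc1nnc(S)n2c(C)nc(C)c12` differs from compound 3 by methyl in place of hydrogen on an aromatic carbon, the same change made from compound 2 to compound 1. Because the step that the two limits leave unreadable from compound 2 to compound 1 gives no size to read, the expected step from compound 3 to compound 4 is a step that the limit leaves unreadable from compound 3 to compound 4. Compound 4 is estimated at 60000 nM, expected between 20000 nM and 200000 nM.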

Compound 4, half-maximal inhibitory concentration: > 48000 nM
Compound 4: no number, only a limit; the forecaster's own chance of this, stated with the estimate: 85%; the middle value does not contradict the limit.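

Compound 3 and compound 4 both give only a limit of the assay, not a number, so no step can be read between them: the limit of > 48000 nM in this assay, at which 4 of the 4 values shown sit.

The compounds shown leave open whether methyl in place of hydrogen changes inhibition at all in this assay.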